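Thiophen-3-yl for thiazolyl on the amide carbonyl

A few compounds are considered here, and "the series" means these few. Any claim that something is new, unique, unknown or untested is made for them only; others in the source may bear on it.

compound 1 `CCCCCCCCCCCC[C@@H](O)[C@H]1CC[C@H]([C@H](O)CCCCCCCCCCNC(=O)c2ccoc2)O1`: 550 nM
compound 2 `CCCCCCCCCCCC[C@@H](O)[C@H]1CC[C@H]([C@H](O)CCCCCCCCCCNC(=O)c2cncs2)O1`: 832 nM

Both compounds were tested in a functional assay on MKN-28 cells (Homo sapiens) for inhibition, read by colorimetric assay and sulforhodamine B assay, with a stated time of 48 h; on this read-out lower numbers stand for stronger inhibition of growth and higher numbers for weaker inhibition of growth. For the measured compounds named here, on these numbers, compound 2 at 832 nM lies within the scatter of its only neighbour, compound 1 at 550 nM.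

The next compound, compound 3 `CCCCCCCCCCCC[C@@H](O)[C@H]1CC[C@H]([C@H](O)CCCCCCCCCCNC(=O)c2ccsc2)O1`, is still to be measured in this assay. It differs from compound 2 as follows: thiophen-3-yl in place of 1,3-thiazol-5-yl on a carbonyl carbon. In words, thiophen-3-yl stands in place of 1,3-thiazol-5-yl on a carbonyl carbon whose other neighbour is the amide-type nitrogen.

Going by the values given here, one measured step bears on this change, and only indirectly. Compound 1 and compound 2 also differ by one five-membered aromatic ring for another at the same place, and that exchange gave a 1.5-fold higher number from compound 1 to compound 2 (0.18 log units; within the scatter). A step of similar size is therefore expected here, with none beyond the scatter and no firm direction.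

The estimated step is a 1.2-fold lower number from compound 2 to compound 3 (0.08 log units; within the scatter). Compound 3 is expected at 700 nM, with an estimated range from 350 nM to 1400 nM.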

Compound 3, concentration for 50% growth inhibition: 575 nM
Compound 3: middle estimate off by 1.2-fold (0.09 log units), on the high side, within the range that was stated.
By their numbers in this assay, from the lowest: compounds 1, 3 and 2 (each within the scatter of the next).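

In this assay, thiophen-3-yl in place of 1,3-thiazol-5-yl gives a 1.4-fold lower number from compound 2 to compound 3 (0.16 log units; within the scatter) and thiophen-3-yl in place of furan-3-yl gives a 1.0-fold higher number from compound 1 to compound 3 (0.02 log units; within the scatter) so all three pairs among these rings on the carbonyl carbon now lie within the scatter. The earlier pair showed this for one exchange only; the new compound shows it for a ring holding only carbon and sulfur, with 1 hetero atom and 1 hydrogen-bond acceptor, against 1,3-thiazol-5-yl with 2 of each, so these counts make no readable difference among the three compounds in this assay. Nothing at hand explains why the three rings read alike.

As far as these compounds go, whether this place accepts anything other than a five-membered aromatic ring, such as a phenyl or pyridine ring, or a ring carrying an amine or a carboxylic acid, remains open. Also open, from the compounds shown here alone, is whether the same flat picture would hold with a shorter or longer chain between the amide-type nitrogen and the shared core, since all three compounds carry the same chain.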